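This account rests on a few compounds, and the source may have more. Where it says the series, first, only, none or still open, it means among the compounds named here.

Three dihydropyrimidinone derivatives were tested for displacement of a labelled ligand from the human A3 adenosine receptor in an assay on HeLa cells for displacement of a labelled ligand from adenosine receptor A3 (Homo sapiens), read by radioligand binding, with a stated time of 180 min, tested at 1 uM; a higher number here means more inhibition at the concentration tested (going by the name of the read-out), a lower number less inhibition. Compound 1, `CC(C)OC(=O)C1=C(C(F)(F)F)NC(=O)NC1c1ccco1`, gives 5%; compound 3, `CC1=C(C(=O)OC(C(F)(F)F)C(F)(F)F)C(c2ccco2)NC(=O)N1`, gives 2%; and compound 2, `CC1=C(C(=O)OC(C(F)(F)F)C(F)(F)F)C(c2cccs2)NC(=O)N1`, gives 1%. All three numbers lie within the scatter of one another, so no order among them can be read.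

Compound 2 arises from compound 3 by the change (thiophen-2-yl in place of furan-2-yl on a saturated ring carbon), and the measured step was a number 1 percentage points lower from compound 3 to compound 2 (within the scatter). The same kind of change leads from compound 1 to compound 4, `CC(C)OC(=O)C1=C(C(F)(F)F)NC(=O)NC1c1cccs1`, as thiophen-2-yl in place of furan-2-yl on a saturated ring carbon; here the saturated ring carbon sits next to the ring atom that bears an isopropoxycarbonyl group and two ring bonds from the ring atom that bears a trifluoromethyl group, whereas in compound 3 it sits next to the ring atom that bears a large group and two ring bonds from the ring atom that bears a methyl group. The difference between the two cores is not broken down here.

Because the step of a number 1 percentage points lower from compound 3 to compound 2 (within the scatter) stayed within the scatter, compound 4 is expected to show a step of about a number 1 percentage points lower from compound 1 to compound 4 (within the scatter) in this assay. Compound 4 is therefore estimated at 4%, with a likely range from -6% to 14%.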

Compound 4, a percentage reported as inhibition, at one concentration (the size of the read-out at that concentration, not a potency): 7%
Estimate against measurement, compound 4: 3 percentage points below, and the stated range covers the measured number.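

The change from furan-2-yl to thiophen-2-yl on the core of compound 1 gave a step of a number 2 percentage points higher from compound 1 to compound 4 (within the scatter), and it carried over from one core to the other in this assay with no difference that can be read: the same change on two cores in this assay, a number 1 percentage points lower (within the scatter) from compound 3 to compound 2 and a number 2 percentage points higher (within the scatter) from compound 1 to compound 4, 3 percentage points apart, within the scatter of two such steps This shows that the change left the number within the scatter on both cores. It does not show that the change would carry over in the same way on a compound with a clearly larger inhibition, as all four values are small.

The compounds shown leave open what a phenyl ring would do in place of furan-2-yl or thiophen-2-yl. They also leave open what a carboxylic acid or an amide would do in place of the ester.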